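The source may report more compounds than this note shows. Statements on the series, on what has been measured and on what is new or still open speak of the compounds shown alone.

Measured so far:
Compound 1, `CN1CCN(CCNCc2cn(-c3ccc(F)cc3F)nc2C2CCCCC2)CC1`: > 20000 nM
Compound 2, `Cc1ccccc1-c1nn(-c2ccc(N)cc2)cc1CNCCN1CCN(C)CC1`: > 20000 nM

In an ADME assay on Huh-7 cells (Homo sapiens) for cytotoxicity (on this read-out higher numbers stand for lower toxicity in this test and lower numbers for higher toxicity in this test), compound 1 reaches only a limit of the test, > 20000 nM. In this assay compound 2 likewise reaches only a limit, > 20000 nM. Both results sit at the limit of > 20000 nM in this assay, at which 2 of the 2 values shown sit, so compound 2 stands exactly where compound 1 stands, with no number beyond the limit. Compound 3, `Cc1ccccc1-c1nn(-c2ccc(F)cc2)cc1CNCCN1CCN(C)CC1`, has not yet been measured; it differs from compound 2 by fluoro in place of amino on an aromatic carbon. Among the compounds with values here, no measured step of this kind is available, so the step that the limit leaves unreadable from compound 2 to compound 3 is expected to stay within the usual scatter. Compound 3 is therefore expected to give about 25000 nM, within 10000 nM to 80000 nM.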

Compound 3, half-maximal cytotoxic concentration: > 20000 nM
Compound 3 was reported as a limit (the forecaster's own chance of this, stated with the estimate: 85%); the middle value lies beyond the limit too.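

Within the data shown here, compound 3 gives > 20000 nM, which is a limit and not a number, so no step from compound 2 to compound 3 can be read: the limit of > 20000 nM in this assay, at which 3 of the 3 values shown sit.

On these data alone, whether compound 1, compound 2 and compound 3 differ at all in this assay stays open.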